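Methyl to methoxy on the benzyloxy ring of a diaryl ether amine series

This account rests on a few compounds, and the source may have more. Where it says the series, first, only, none or still open, it means among the compounds named here.

Of the compounds shown here, two have been measured in a functional assay on PC-3 cells (Homo sapiens) for cytotoxicity, read by sulforhodamine B assay; on this read-out lower numbers stand for stronger inhibition of growth and higher numbers for weaker inhibition of growth. Compound 1 `COc1cccc(OC)c1OCCNCCOc1ccccc1OCc1cccc(C)c1` gives 32300 nM, and compound 2 `COc1cccc(OC)c1OCCNCCOc1ccccc1OCc1ccc(C)cc1` gives 27500 nM. For the measured compounds named here, the only step so far, a 1.2-fold lower number from compound 1 to compound 2 (0.07 log units; within the scatter), moves the methyl on the outer ring, so compound 2 stands alongside compound 1 with no separation beyond the scatter.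

Compound 3 `COc1ccc(COc2ccccc2OCCNCCOc2c(OC)cccc2OC)cc1` is not yet measured. It differs from compound 2 by methoxy in place of methyl on an aromatic carbon. No measured step bears directly on this change; the one step shown, a 1.2-fold lower number from compound 1 to compound 2 (0.07 log units; within the scatter), concerns the position of the methyl rather than its replacement, and it sat within the scatter. With nothing in the data pointing either way, the expectation for a 1.1-fold lower number from compound 2 to compound 3 (0.04 log units; within the scatter) is a step not beyond the scatter. Compound 3 is therefore estimated at 25000 nM, with a plausible range from 10000 nM to 60000 nM.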

Compound 3, concentration for total growth inhibition: 34700 nM
Compound 3: middle estimate off by 1.4-fold (0.14 log units), on the low side, within the range that was stated.
By their numbers in this assay, from the lowest: compounds 2, 1 and 3 (each within the scatter of the next).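

In this assay, methoxy in place of methyl on the aromatic carbon gives a 1.3-fold higher number from compound 2 to compound 3 (0.10 log units; within the scatter) and stays within the scatter, although the change adds a hydrogen-bond acceptor to the outer ring. The wider comparison, 4-methoxyphenyl in place of 3-methylphenyl, gives a 1.1-fold higher number from compound 1 to compound 3 (0.03 log units; within the scatter) and is also within the scatter, so neither the methyl position nor this swap to methoxy separates the three compounds on this read-out. No supporting data bear on this result, so the flat outcome stays a plain observation.

As far as these compounds go, all three compounds carry a small neutral group on the outer ring, so the effect of an amine or a carboxylic acid at this position remains open. Also open, from the compounds shown here alone, is whether any change here, or a longer chain between the two nitrogen-flanking ether oxygens, would move the number beyond the scatter.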